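From an Amide-Bearing Ether to a Hexyloxy Chain

This account rests on a few compounds, and the source may have more. Where it says the series, first, only, none or still open, it means among the compounds named here.

Within the data shown here, in an assay for inhibition of Dihydrofolate reductase (Gallus gallus) (on this read-out higher numbers stand for weaker inhibition and lower numbers for stronger inhibition), compound 3 `NC(=O)COc1ccccc1Cc1cnc(N)nc1N` gives 33900 nM, the highest of the three numbers measured so far. For comparison, compound 1 `Cc1ccccc1Cc1cnc(N)nc1N` gives 29500 nM, and compound 2 `CCCCOc1ccccc1Cc1cnc(N)nc1N` gives 8710 nM. Compound 4 `CCCCCCOc1ccccc1Cc1cnc(N)nc1N` differs from compound 3 in one place: pentyl in place of carbamoyl on a saturated chain carbon bound to an oxygen on an aromatic ring. Among the measured compounds shown here, two measured steps bear on this change. The step of a 3.9-fold higher number from compound 2 to compound 3 (0.59 log units; beyond the scatter) runs in the opposite direction to the present change, and the step of a 3.4-fold lower number from compound 1 to compound 2 (0.53 log units; beyond the scatter) points the same way, with a plain alkyl ether giving the lower number. On that basis compound 4 is expected to give a modestly lower number than compound 3, a step of about a 4.8-fold lower number from compound 3 to compound 4 (0.69 log units; beyond the scatter). The estimate for compound 4 is 7000 nM, with a range from 2500 nM to 20000 nM.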

Compound 4, inhibition constant: 7940 nM
The estimate for compound 4 lay 1.1-fold (0.05 log units) below the measured number; measured number inside the range.
By their numbers in this assay, from the lowest: compounds 4 and 2 (each within the scatter of the next); then compounds 1 and 3 (each within the scatter of the next).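

Pentyl in place of carbamoyl gives a 4.3-fold lower number from compound 3 to compound 4 (0.63 log units; beyond the scatter) and hexyloxy in place of methyl gives a 3.7-fold lower number from compound 1 to compound 4 (0.57 log units; beyond the scatter), so a second plain alkyl ether now reaches the lower level first seen with butoxy. Adding ethyl to the butoxy chain gives a 1.1-fold lower number from compound 2 to compound 4 (0.04 log units; within the scatter), so at this position the longer chain brings no measurable difference. No measurement here explains these steps. On these data alone, whether a still longer chain, such as octyloxy, would hold this level stays open, as does whether an amine or a carboxylic acid at the chain end would match the amide of compound 3.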